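Cyclohexylamino variant of the enaminone series

A few compounds are considered here, and "the series" means these few. Any claim that something is new, unique, unknown or untested is made for them only; others in the source may bear on it.

Working notes on the series. Compound 1 `CCCNC(=C\C(=O)/C=C/c1ccc(O)c(OC)c1)/C=C/c1ccc(O)c(OC)c1` carries a propylamino group on the shared core. In a functional assay on HT-29 cells (Homo sapiens) for inhibition, read by sulforhodamine B assay, with a stated time of 72 h (on this read-out higher numbers stand for weaker inhibition and lower numbers for stronger inhibition), compound 1 gives > 25000 nM, which is a limit of the assay and not a number. Compound 2 `COc1cc(/C=C/C(=O)/C=C(/C=C/c2ccc(OC(C)=O)c(OC)c2)NCC(C)C)ccc1OC(C)=O` is the second measured member of the series. In this assay compound 2 gives > 25000 nM, again a limit rather than a number. On the numbers shown, compound 1 stands only at the limit of > 25000 nM in this assay, at which 2 of the 2 values shown sit; two limits allow no ordering of compound 1 against compound 2, and no step between measured compounds can be stated.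

Compound 3 `COc1cc(/C=C/C(=O)/C=C(/C=C/c2ccc(O)c(OC)c2)NC2CCCCC2)ccc1O` differs from compound 1 by cyclohexyl in place of propyl on an amine nitrogen. Going by the values given here, no measured step tells what this change does in this assay. Because compound 1 gives > 25000 nM, a limit, the step expected from it is a step that the limit leaves unreadable from compound 1 to compound 3, none beyond the scatter. Compound 3 is expected to give 30000 nM in this assay, within a range from 10000 nM to 100000 nM, most probably reported again as a limit.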

Compound 3, half-maximal inhibitory concentration: > 25000 nM
Compound 3: no number, only a limit; the forecaster's own chance of this, stated with the estimate: 75%; the middle value does not contradict the limit.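

No new step can be read from compound 1 to compound 3, since each gives only a limit in this assay and not a number: the limit of > 25000 nM in this assay, at which 3 of the 3 values shown sit.

The compounds shown leave open whether any change on the shared core yields a number in this assay and what cyclohexyl in place of propyl does.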